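Chloro to acetamido: the step from compound 3 to compound 4

The compounds below may be only part of what the source reports. "The series", "measured", "known", "first", "only" and "open" are said of these compounds alone.

For the measured compounds named here, compound 3 `N#CC1=C(N)Oc2c(N)cc3nc4ccccc4nc3c2C12C(=O)N(Cc1cnnn1-c1ccc(Cl)cc1)c1ccccc12` is one of three compounds measured in an ADME assay on L02 cells (Homo sapiens) for antiproliferative activity, read by MTT assay, with a stated time of 48 h; a higher number here means a weaker inhibitor, a lower number a stronger inhibitor. In this assay compound 3 gives > 50000 nM, which is a limit of the assay rather than a number. Compound 1 `N#CC1=C(N)Oc2c(c3nc4ccccc4nc3c3ccccc23)C12C(=O)N(Cc1cnnn1-c1ccccc1Cl)c1ccccc12` gives > 50000 nM, also a limit. Compound 2 `N#CC1=C(N)Oc2c(c3nc4ccccc4nc3c3ccccc23)C12C(=O)N(Cc1cnnn1-c1ccccc1Br)c1ccccc12` gives > 50000 nM, again a limit. Going by the values given here, the only step between measured compounds that differ in one place, a step that the two limits leave unreadable from compound 1 to compound 2, has both ends at the limit and cannot be read. the limit of > 50000 nM in this assay, at which 3 of the 3 values shown sit, sums up where things stand: every measured value sits at the same limit.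

Compound 4 `CC(=O)Nc1ccc(-n2nncc2CN2C(=O)C3(C(C#N)=C(N)Oc4c(N)cc5nc6ccccc6nc5c43)c3ccccc32)cc1` differs from compound 3 by acetamido in place of chloro on an aromatic carbon. Among the compounds with values here, no measured step bears on this change, since the one measured step, bromo for chloro, is unreadable. With all three values at the limit and no readable step, no shift in this assay beyond the scatter is expected. Compound 4 is therefore expected to give 80000 nM, within 25000 nM to 300000 nM, most likely reported again only as a limit. The expected step that the limit leaves unreadable from compound 3 to compound 4 is accordingly close to none.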

Compound 4, half-maximal inhibitory concentration: > 50000 nM
Compound 4 ended at the assay's limit; the forecaster's own chance of this, stated with the estimate: 85%; the middle value is on the limit's open side.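

Compound 3 and compound 4 each give only a limit of the assay, so no step can be read for acetamido in place of chloro. The whole set stands the same way: the limit of > 50000 nM in this assay, at which 4 of the 4 values shown sit.

The compounds shown leave open whether any change to them would bring a readable value in this assay.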